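The source may report more compounds than this note shows. Statements on the series, on what has been measured and on what is new or still open speak of the compounds shown alone.

Measured in a functional assay on PC-3 cells (Homo sapiens); on this read-out lower numbers stand for stronger inhibition of growth and higher numbers for weaker inhibition of growth:
- compound 1 `COc1cccc(-c2cc(O)c3c(C)cc(C)nc3n2)c1`: 309 nM
- compound 2 `COc1cccc(-c2cc(O)c3cc(C)cnc3n2)c1`: 42.7 nM
- compound 3 `COc1cccc(-c2cc(O)c3c(C)ccnc3n2)c1`: 26.3 nM

Compound 3 and compound 2 lie within the scatter of each other at the low end of the numbers, and compound 1 stands well apart. Compound 4 `COc1cccc(-c2cc(O)c3cccnc3n2)c1` follows from compound 3 by hydrogen in place of methyl on an aromatic carbon, opposite the ring nitrogen. Going by the values given here, the only measured step of this kind removes a different methyl and is large: a 12-fold lower number from compound 1 to compound 3 (1.07 log units; beyond the scatter). Among the compounds with values here, it is a weak guide here, and no measured compound lacks methyl on the core altogether. Since compound 3 already sits at the low end with 26.3 nM, a moderate move in this assay towards a higher number is expected: a 2.3-fold higher number from compound 3 to compound 4 (0.36 log units; beyond the scatter). For compound 4 the estimated value is 60 nM, with an expected range of 15 nM to 250 nM.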

Compound 4, concentration for 50% growth inhibition: 93.3 nM
Estimate against measurement, compound 4: 1.6-fold (0.19 log units) below, and the stated range covers the measured number.
By their numbers in this assay, from the lowest: compounds 3 and 2 (each within the scatter of the next); then compound 4; then compound 1.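

In this assay, going by these compounds alone, the core without methyl is the first reference for this position: hydrogen in place of the methyl opposite the ring nitrogen gives a 3.5-fold higher number from compound 3 to compound 4 (0.55 log units; beyond the scatter). Hydrogen in place of the other single methyl gives a 2.2-fold higher number from compound 2 to compound 4 (0.34 log units; beyond the scatter), so on these two cores the change raises the number. The step from compound 1 goes against this, and the same change does not carry from one core to the other: the same change on two cores in this assay, a 12-fold lower number (1.07 log units; beyond the scatter) from compound 1 to compound 3 and a 2.2-fold higher number (0.34 log units; beyond the scatter) from compound 2 to compound 4, 26-fold (1.41 log units) apart, beyond the scatter of two such steps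

The compounds shown leave open how an ethyl chain or an amine on the carbon opposite the ring nitrogen would read in this assay.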